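Ethynyl to isopropyl on the amide carbonyl

A few compounds are considered here, and "the series" means these few. Any claim that something is new, unique, unknown or untested is made for them only; others in the source may bear on it.

Of the compounds shown here, three have numbers so far. In a functional assay on MGC-803 cells (Homo sapiens) for inhibition, read by MTT assay, with a stated time of 48 h (a lower number here means a stronger inhibitor, a higher number a weaker inhibitor), compound 3 `C#CC(=O)N(Cc1ccc(OC)c(O)c1)c1cc(OC)c(OC)c(OC)c1` gives 170 nM, the lowest of the three. Compound 1 `C/C=C/C(=O)N(Cc1cc(OC)c(OC)c(OC)c1)c1ccc(OC)c(O)c1` gives 6150 nM in this assay, and compound 2 `COc1ccc(CNc2cc(OC)c(OC)c(OC)c2)cc1Br` gives 29400 nM. The gap from compound 3 to compound 1 and the gap from compound 3 to compound 2 both lie beyond the usual scatter, so compound 3 is the strongest inhibitor of the three as measured.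

Compound 4 `COc1ccc(CN(C(=O)C(C)C)c2cc(OC)c(OC)c(OC)c2)cc1O` has not been measured. It differs from compound 3 in a single place: isopropyl in place of ethynyl on a carbonyl carbon. Among the measured compounds shown here, no measured pair isolates this change, so its size has to be judged from the spread of the three numbers alone. That spread is wide, and the two compounds carrying something other than the ethynylcarbonyl, compound 1 at 6150 nM and compound 2 at 29400 nM, both sit far above compound 3.

The expectation for compound 4 is therefore a weakening, estimated as a step of a 47-fold higher number from compound 3 to compound 4 (1.67 log units; beyond the scatter) in this assay. Compound 4 is expected to give about 8000 nM, with a plausible range from 1500 nM to 40000 nM.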

Compound 4, half-maximal inhibitory concentration: 210 nM
Compound 4: middle estimate off by 38-fold (1.58 log units), on the high side; measured number outside the range, below it.
By their numbers in this assay, from the lowest: compounds 3 and 4 (each within the scatter of the next); then compound 1; then compound 2.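

In this assay, among the compounds shown here, isopropyl in place of ethynyl on a carbonyl carbon gives a 1.2-fold higher number from compound 3 to compound 4 (0.09 log units; within the scatter) and is the first change at this place that can be read on its own. The triple bond of the ethynyl is therefore not needed for compound 4 to match compound 3 within the scatter, and across these two groups the place shows no dependence on that bond or on the count of two versus three carbons. No measurement at hand accounts for this match.

Going by these compounds, two groups say little about how wide this tolerance is, so it remains open whether a longer chain, a cyclopropyl ring or an amine on the same carbonyl carbon would keep the number at this level. Also open is what the carbonyl itself contributes, as no pair shown changes it alone while keeping the rest of the shared core intact.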